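A Bulkier Saturated Ring on the Aromatic Nitrogen

A few compounds are considered here, and "the series" means these few. Any claim that something is new, unique, unknown or untested is made for them only; others in the source may bear on it.

Of the compounds shown here, three sharing one core have been measured in an assay on isolated protein for inhibition of histone acetyltransferase p300 (Homo sapiens), read by AlphaLISA, with a stated time of 20 min; a lower number here means a stronger inhibitor, a higher number a weaker inhibitor. Compound 1 `COc1ccc(CCc2nc3cc(-c4c(C)noc4C)ccc3n2[C@H]2CC[C@H](OC)CC2)cc1Cl` gives 97 nM, compound 2 `COc1ccc(CCc2nc3cc(-c4c(C)noc4C)ccc3n2C2CCC(F)(F)CC2)cc1Cl` gives 83 nM, and compound 3 `COc1ccc(CCc2nc3cc(-c4c(C)noc4C)ccc3n2[C@H]2CC[C@H](C(F)(F)F)CC2)cc1Cl` gives 894 nM. Among these three, compound 1 stands second highest; its nearest neighbour is compound 2, with a 1.2-fold lower number from compound 1 to compound 2 (0.07 log units; within the scatter), and its furthest is compound 3, with a 9.2-fold higher number from compound 1 to compound 3 (0.96 log units; beyond the scatter). The comparison between compound 2 and compound 3 shows an 11-fold higher number from compound 2 to compound 3 (1.03 log units; beyond the scatter).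

Compound 4 `COc1ccc(CCc2nc3cc(-c4c(C)noc4C)ccc3n2C2CC(C)(C)OC(C)(C)C2)cc1Cl` is not yet measured. Relative to compound 1, the change is 2,2,6,6-tetramethyloxan-4-yl in place of 4-methoxycyclohexyl on an aromatic nitrogen.

Two of the measured steps bear on this. The move from compound 1 to compound 2 shows that exchanging the substituent on the saturated ring can leave the number unchanged, while the steps to compound 3 show that another exchange on that ring can raise it substantially. The tetramethyloxane ring of compound 4 is a different kind of change again: it adds two heavy atoms and a ring oxygen in place of the methoxy carbon ring. Among the measured compounds shown here, with no direct precedent, the expectation for compound 4 in this assay is a step of a 3.1-fold higher number from compound 1 to compound 4 (0.49 log units; beyond the scatter), toward a weaker inhibitor. Compound 4 is therefore estimated at 300 nM, within a range from 80 nM to 1500 nM.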

Compound 4, half-maximal inhibitory concentration: 112 nM
Compound 4: middle estimate off by 2.7-fold (0.43 log units), on the high side, within the range that was stated.
By their numbers in this assay, from the lowest: compounds 2, 1 and 4 (each within the scatter of the next); then compound 3.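

In this assay, placing 2,2,6,6-tetramethyloxan-4-yl on the aromatic nitrogen gives a 1.2-fold higher number from compound 1 to compound 4 (0.06 log units; within the scatter) and a 1.3-fold higher number from compound 2 to compound 4 (0.13 log units; within the scatter), so this ring cannot be told apart from either 4-methoxycyclohexyl or 4,4-difluorocyclohexyl at this position. The same group gives an 8.0-fold lower number from compound 3 to compound 4 (0.90 log units; beyond the scatter), which leaves compound 3 as the only one of the four set apart from the others and shows that 10 heavy atoms in the entering group, against 8 in the group it replaces, need not shift the number at this position, even with the ring oxygen and four methyl groups present together. Nothing available here accounts for why compound 3 stands apart from the other three.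

The compounds shown leave open whether the four methyl groups matter at all, since the plain oxan-4-yl ring does not appear among them, and whether the ring oxygen can give way to a piperidine nitrogen. They also leave open how a carboxylic acid or a primary amine on the cyclohexyl ring would read in this assay.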